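The source may hold more compounds than are shown below. What is called first, only, known or untested is meant among the compounds shown, and "the series" means these compounds.

- Compound 1 `CC(C)[C@H](NC(=O)COc1cccc2ccccc12)C(=O)N[C@@H](CC(=O)O)C(=O)COc1ccc([N+](=O)[O-])cc1`: > 100000 nM, a limit
- Compound 2 `CC(C)[C@H](NC(=O)COc1cccc2ccccc12)C(=O)N[C@@H](CC(=O)O)C(=O)COc1ccc(F)c(F)c1`: > 100000 nM, a limit

In a functional assay on Jurkat cells (Homo sapiens) (a higher number here means a weaker inhibitor, a lower number a stronger inhibitor), compound 2 is known only by its limit of > 100000 nM, with no number behind it. Compound 1 also gives only a limit, and the evidence is simply (the limit of > 100000 nM in this assay, at which 2 of the 2 values shown sit).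

Compound 3 `CC(C)[C@H](NC(=O)COc1cccc2ccccc12)C(=O)N[C@@H](CC(=O)O)C(=O)COc1ccc(F)c(F)c1F` differs from compound 2 by fluoro in place of hydrogen on an aromatic carbon, which turns 3,4-difluorophenoxy into 2,3,4-trifluorophenoxy.

Among the measured compounds shown here, the one measured step that bears on this is the exchange of 4-nitrophenyl for 3,4-difluorophenyl, a step that the two limits leave unreadable from compound 1 to compound 2. It therefore gives no size to carry over, and neither direction is favoured in this assay. The expected result is no readable change, and a number no higher from compound 2 to compound 3 (the limit leaves the size open) is only an estimate. Compound 3 is expected at about 100000 nM, with an estimated range of 30000 nM to 300000 nM.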

Compound 3, half-maximal inhibitory concentration: 35800 nM
For compound 3 the middle estimate is 2.8-fold (0.45 log units) above the measured one; measured number inside the range.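

In this assay, among the compounds shown here, a fluoro group on this aromatic carbon, ortho to a fluoro group, gives the first reading in this set that is a number and not a limit: an at least 2.7-fold lower number from compound 2 to compound 3 (0.44 log units; beyond the scatter). The full exchange of the 4-nitrophenyl group for 2,3,4-trifluorophenyl gives an at least 2.7-fold lower number from compound 1 to compound 3 (0.44 log units; beyond the scatter), while the step between the two earlier compounds cannot be read. Each size is only a minimum, for the starting compounds stand at a limit of the assay: the limit of > 100000 nM in this assay, at which 2 of the 3 values shown sit.

The compounds shown leave open whether the lower number is tied to this position or to the count of fluoro groups on the ring. They also leave open how a chloro or a methoxy group on this same aromatic carbon would read in this assay.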